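Thiophene in place of dimethylphenyl on a urea nitrogen

The source may hold more compounds than are shown below. What is called first, only, known or untested is meant among the compounds shown, and "the series" means these compounds.

Compound 1, `O=C(Nc1ccc(Br)cc1)Nc1ccc(Nc2ncnc3c2OCCN3)cc1`, gives > 10000 nM in an assay on isolated protein for inhibition of proto-oncogene tyrosine-protein kinase receptor Ret variant V804L (Homo sapiens), read by 33P incorporation, with stated times of 15 min and 40 min; a lower number here means a stronger inhibitor, a higher number a weaker inhibitor.
Compound 2, `COc1cccc(NC(=O)Nc2ccc(Nc3ncnc4c3OCCN4)cc2)c1`, gives > 10000 nM.
Compound 3, `Cc1cc(C)cc(NC(=O)Nc2ccc(Nc3ncnc4c3OCCN4)cc2)c1`, gives 3770 nM.

The value of compound 1 is a limit of the assay, not a number. The value of compound 2 is likewise a limit. Compound 3 holds the only number shown, so it stands alone as the measured point. The steps of an at least 2.6-fold lower number from compound 1 to compound 3 (0.42 log units; beyond the scatter) and an at least 2.6-fold lower number from compound 2 to compound 3 (0.42 log units; beyond the scatter) are both at least modest in the same direction. Compound 4, `O=C(Nc1ccc(Nc2ncnc3c2OCCN3)cc1)Nc1cccs1`, differs from compound 3 by thiophen-2-yl in place of 3,5-dimethylphenyl on an amide-type nitrogen. For the measured compounds named here, no measured step tests a five-membered ring here, and two of three values sit at the limit of > 10000 nM in this assay, at which 2 of the 3 values shown sit, so weak inhibition is common in this set. Compound 4 is expected to give 7000 nM, within 2000 nM to 25000 nM, an expected step of a 1.9-fold higher number from compound 3 to compound 4 (0.27 log units; within the scatter).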

Compound 4, half-maximal inhibitory concentration: > 10000 nM
Compound 4 gave a limit, no number; the forecaster's own chance of this, stated with the estimate: 45%; at least 1.4-fold (0.15 log units) between middle value and limit.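

On the amide-type nitrogen, thiophen-2-yl in place of 3,5-dimethylphenyl gives an at least 2.6-fold higher number from compound 3 to compound 4 (0.42 log units; beyond the scatter) in this assay, and this is the only five-membered ring shown at this position. The steps from compound 1 and from compound 2 to compound 4 join two limits and cannot be read. For the compounds shown here, compound 3 remains the only compound with a number, and the others all share one limit of the assay: the limit of > 10000 nM in this assay, at which 3 of the 4 values shown sit.

The compounds shown leave open whether both methyl groups of 3,5-dimethylphenyl are needed, which 3-methylphenyl would test. They also leave open whether a pyridine ring or a longer chain carrying an amine on this nitrogen would give a stronger inhibitor.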